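A Fluorinated Anilide Swap on the Shared Core

The source may report more compounds than this note shows. Statements on the series, on what has been measured and on what is new or still open speak of the compounds shown alone.

Three compounds of one series share a core and differ only in the aryl group on an amine nitrogen. Compound 1 `Cc1ccc(S(=O)(=O)/N=C(/CCNC2=CC(=O)c3ccccc3C2=O)Nc2ccc(F)cc2)cc1` carries a 4-fluorophenyl there and in a functional assay on DU-145 cells (Homo sapiens) for cytotoxicity, read by MTT assay, with a stated time of 48 h (on this read-out lower numbers stand for stronger inhibition and higher numbers for weaker inhibition), compound 1 gives 12200 nM. Compound 2 `Cc1ccc(S(=O)(=O)/N=C(/CCNC2=CC(=O)c3ccccc3C2=O)Nc2cccc(C)c2)cc1` carries a 3-methylphenyl, and in this assay compound 2 gives 10200 nM; the pair shows a 1.2-fold lower number from compound 1 to compound 2 (0.08 log units; within the scatter). Compound 3 `Cc1ccc(S(=O)(=O)/N=C(/CCNC2=CC(=O)c3ccccc3C2=O)Nc2cccc(C(F)(F)F)c2)cc1` carries a 3-(trifluoromethyl)phenyl, and in this assay compound 3 gives 84100 nM, the highest number of the three: there is a 6.9-fold higher number from compound 1 to compound 3 (0.84 log units; beyond the scatter) and an 8.2-fold higher number from compound 2 to compound 3 (0.92 log units; beyond the scatter).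

Compound 4 `Cc1ccc(S(=O)(=O)/N=C(/CCNC2=CC(=O)c3ccccc3C2=O)Nc2ccc(F)c(F)c2)cc1` is the next step: 3,4-difluorophenyl in place of 3-(trifluoromethyl)phenyl on an amine nitrogen. The two measured steps that bear on it both involve the trifluoromethyl-bearing ring of compound 3, and both were modest losses on arrival at that ring. Removing that ring in favour of a difluorophenyl should therefore return most of that ground, since compound 1, which carries a single fluorine on its ring, stands at 12200 nM. Compound 4 is thus expected to show a 6.0-fold lower number from compound 3 to compound 4 (0.78 log units; beyond the scatter) in this assay, a lower number. The estimate for compound 4 is 14000 nM, in a range from 6000 nM to 35000 nM.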

Compound 4, half-maximal inhibitory concentration: 12900 nM
Compound 4: the middle estimate sits 1.1-fold (0.04 log units) above what was measured; the range from low to high includes it.
By their numbers in this assay, from the lowest: compounds 2, 1 and 4 (each within the scatter of the next); then compound 3.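

With a 6.5-fold lower number from compound 3 to compound 4 (0.81 log units; beyond the scatter) in this assay, the change shows that the high number of compound 3 does not extend to every fluorine-bearing ring at this amine nitrogen: the 3,4-difluorophenyl group does not carry that loss. Adding a second fluorine to the ring of compound 1 gives a 1.1-fold higher number from compound 1 to compound 4 (0.02 log units; within the scatter), and replacing the 3-methylphenyl of compound 2 gives a 1.3-fold higher number from compound 2 to compound 4 (0.10 log units; within the scatter), so the 4-fluorophenyl, 3-methylphenyl and 3,4-difluorophenyl groups form a set that the scatter does not separate, with compound 3 alone standing apart. No supporting measurement bears on why the trifluoromethyl-bearing ring differs from the others.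

The compounds shown leave open whether a chlorine, a methoxy group or a nitrile on the aromatic ring would stay with compounds 1, 2 and 4 or move towards compound 3. They also leave open whether an unsubstituted phenyl or a saturated cyclohexyl on this amine nitrogen would give a number clearly lower than that set, since all four groups here are substituted phenyl rings.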